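A Methyl Group on the Phenyl of Compound 1

A few compounds are considered here, and "the series" means these few. Any claim that something is new, unique, unknown or untested is made for them only; others in the source may bear on it.

Of the compounds shown here, three sharing one core have been measured in a functional assay on MGC-803 cells (Homo sapiens) for antiproliferative activity, read by CCK-8 assay, with a stated time of 72 h, tested at 2 uM; a higher number here means a stronger effect of the compound at the concentration tested, a lower number a weaker effect. Compound 1 `Nc1ccccc1NC(=O)c1ccc(CSC(=S)N2CCN(c3ccccc3)CC2)cc1` gives 42.3% in this assay, the second highest of the three numbers. Compound 2 `Nc1ccccc1NC(=O)c1ccc(CSC(=S)N2CCCc3ccccc32)cc1` gives 38.5% in this assay, within the scatter of compound 1. Compound 3 `CC1CCCCN1C(=S)SCc1ccc(C(=O)Nc2ccccc2N)cc1` gives 64.4% in this assay, beyond the scatter above compound 1. Going by the values given here, the one step between compounds that differ in a single place is a number 25.9 percentage points higher from compound 2 to compound 3 (beyond the scatter), where 2-methylpiperidin-1-yl replaces 1,2,3,4-tetrahydroquinolin-1-yl on the thiocarbonyl carbon.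

Compound 4 `Cc1ccc(N2CCN(C(=S)SCc3ccc(C(=O)Nc4ccccc4N)cc3)CC2)cc1` is not yet measured. It differs from compound 1 by methyl in place of hydrogen on an aromatic carbon. Among the compounds with values here, that change sits on the phenyl at the far end of the piperazine, not on the thiocarbonyl carbon, so the step from compound 2 to compound 3 does not speak to it; no measured step in this set does. With nothing in the data to point either way, a step no larger than the scatter is expected, as a number 1.7 percentage points higher from compound 1 to compound 4 (within the scatter). Compound 4 is therefore estimated at 44% in this assay, with a range from 30% to 58%.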

Compound 4, a percentage reported as inhibition, at one concentration (the size of the read-out at that concentration, not a potency): 33.4%
Beside the measured number, compound 4's estimate is 10.6 percentage points above it; measured number inside the range.
By their numbers in this assay, from the lowest: compounds 4, 2 and 1 (each within the scatter of the next); then compound 3.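

Going by these compounds alone, replacing phenyl with 4-methylphenyl at the far end of the piperazine gives the first reading of this position in this assay, and the step is a number 8.9 percentage points lower from compound 1 to compound 4 (within the scatter). So methyl in place of hydrogen on this aromatic carbon, para to a large group, leaves the read-out within the usual scatter, whereas the only earlier single-place step, a number 25.9 percentage points higher from compound 2 to compound 3 (beyond the scatter), involved a change of the whole group on the thiocarbonyl carbon and tells nothing about this phenyl. No measured evidence bears on why the methyl step came out as it did, and this one pair gives no reason to read a direction into it.

The compounds shown leave open whether another group at this same aromatic carbon, such as a chlorine atom, a methoxy group, an amine or a carboxylic acid, would shift the number beyond the scatter. They also leave open whether a longer chain such as ethyl or propyl in place of the methyl, or a methyl elsewhere on the phenyl, would do so.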